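Swapping thiophen-3-yl for furan-2-yl on the shared core

The source may report more compounds than this note shows. Statements on the series, on what has been measured and on what is new or still open speak of the compounds shown alone.

Compound 1 `Oc1ccc(-c2cc(-c3ccc(Cl)cc3)nc(-c3ccsc3)c2)cc1`: 6940 nM
Compound 2 `Oc1cccc(-c2cc(-c3ccc(Cl)cc3)nc(-c3ccsc3)c2)c1`: 11600 nM
Compound 3 `Oc1cccc(-c2cc(-c3ccsc3)nc(-c3cccc(Cl)c3)c2)c1`: 3330 nM

Among these three, compound 2 gives the highest number in a functional assay on DU-145 cells (Homo sapiens) for cytotoxicity, read by CCK-8 assay and cell counting, with a stated time of 2 days; on this read-out higher numbers stand for weaker inhibition and lower numbers for stronger inhibition. Compound 1 sits within the scatter of it (a 1.7-fold higher number from compound 1 to compound 2 (0.22 log units; within the scatter)), whereas compound 3 gives a clearly lower number (a 3.5-fold lower number from compound 2 to compound 3 (0.54 log units; beyond the scatter)). Compound 4 `Oc1cccc(-c2cc(-c3ccc(Cl)cc3)nc(-c3ccco3)c2)c1` differs from compound 2 in a single place: furan-2-yl in place of thiophen-3-yl on an aromatic carbon. Neither measured step touches this five-membered ring: one exchanged 4-hydroxyphenyl for 3-hydroxyphenyl, the other 4-chlorophenyl for 3-chlorophenyl. Nothing measured therefore speaks to a swap of thiophen-3-yl for furan-2-yl, and no step beyond the scatter is expected in this assay. The expected step is a 1.1-fold lower number from compound 2 to compound 4 (0.02 log units; within the scatter). Compound 4 is estimated at 11000 nM, with a range from 3500 nM to 35000 nM.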

Compound 4, half-maximal inhibitory concentration: 11400 nM
For compound 4 the middle estimate is 1.0-fold (0.02 log units) below the measured one; low and high end bracket the measured number.
By their numbers in this assay, from the lowest: compound 3; then compounds 1, 4 and 2 (each within the scatter of the next).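

Changing thiophen-3-yl to furan-2-yl next to the ring nitrogen leaves the number in this assay within the scatter (a 1.0-fold lower number from compound 2 to compound 4 (0.01 log units; within the scatter)). The earlier steps shown here changed only the hydroxyphenyl and chlorophenyl groups, whereas this one shows that the five-membered ring can differ in both its hetero atom and its point of attachment without a readable shift. Nothing available explains this result.

Still open, going by these compounds, is how an amine or a longer carbon chain would fare at this position. Also open, on these data alone, is whether furan-2-yl would give the same result alongside the 3-chlorophenyl group of compound 3.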